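Chloro analogue of an anilino ether: permeability expectation

The source may report more compounds than this note shows. Statements on the series, on what has been measured and on what is new or still open speak of the compounds shown alone.

Compound 1 `CNC(=O)c1cc(Oc2ccc3nc(Nc4ccccc4)ncc3c2)ccn1` is measured in an ADME assay on Caco-2 cells (Homo sapiens) for permeability, in the apical to basolateral direction; a lower number here means that the compound crosses the layer more slowly, a higher number that the compound crosses the layer faster; in that assay compound 1 gives < 1 10^-6 cm/s, which is a limit of the assay and not a number. Compound 2 `CNC(=O)c1cc(Oc2ccc3nc(Nc4cccc(C(C)(C)C)c4)cnc3c2)ccn1` is a second member of the series. In this assay compound 2 also gives < 1 10^-6 cm/s, again a limit of the assay. Compound 1 thus stands at the limit of < 1 10^-6 cm/s in this assay, at which 2 of the 2 values shown sit, and nothing places it above or below compound 2. Compound 3 `CNC(=O)c1cc(Oc2ccc3nc(Nc4cccc(Cl)c4)ncc3c2)ccn1` carries the change (chloro in place of hydrogen on an aromatic carbon), chloro in place of hydrogen on an aromatic carbon. Among the compounds with values here, no measured step covers a change of this kind. Compound 3 is expected to remain near the limit because compound 1 sits at < 1 10^-6 cm/s in this assay. The expected step that the limit leaves unreadable from compound 1 to compound 3 is none beyond the scatter. The estimate for compound 3 is 0.6 10^-6 cm/s, with a range from 0.2 10^-6 cm/s to 2 10^-6 cm/s.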

Compound 3, apparent permeability: < 1 10^-6 cm/s
Compound 3 was reported as a limit; the forecaster's own chance of this, stated with the estimate: 75%; the middle value does not contradict the limit.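

Within the data shown here, compound 3 and compound 1 both sit at a limit of the assay, not at a number, so no step between compound 1 and compound 3 can be read. The compounds shown leave open what chloro in place of hydrogen on an aromatic carbon does in this assay, where none of them carries a number: the limit of < 1 10^-6 cm/s in this assay, at which 3 of the 3 values shown sit.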